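Methoxy addition to compound 2: working notes

The compounds below may be only part of what the source reports. "The series", "measured", "known", "first", "only" and "open" are said of these compounds alone.

Measured in an ADME assay on NHDF cells (Homo sapiens) for cytotoxicity, read by MTT assay, with a stated time of 72 h; a lower number here means a stronger inhibitor, a higher number a weaker inhibitor:
- compound 1 `COc1cccc(/C=C2\CCC/C(=C\c3ccc(Br)cc3)C2=O)c1OC` gives 21400 nM
- compound 2 `COc1cccc(/C=C2\CCC/C(=C\c3cccc(OC)c3OC)C2=O)c1` gives 16400 nM

Compound 2 cannot be separated from compound 1 on these numbers, as a 1.3-fold lower number from compound 1 to compound 2 (0.12 log units; within the scatter) stays within the scatter. The next compound to be read is compound 3 `COc1cc(/C=C2\CCC/C(=C\c3cccc(OC)c3OC)C2=O)cc(OC)c1`, which carries methoxy in place of hydrogen on an aromatic carbon, (methoxy in place of hydrogen on an aromatic carbon), meta to a large group and meta to a methoxy group.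

Going by the values given here, no measured step adds a methoxy group. Among the compounds with values here, the only guide is the step of a 1.3-fold lower number from compound 1 to compound 2 (0.12 log units; within the scatter), a swap of 4-bromophenyl for 3-methoxyphenyl that left this assay within the scatter. On that limited evidence, no change beyond the scatter is expected. The expected step is a 1.1-fold lower number from compound 2 to compound 3 (0.04 log units; within the scatter). For compound 3 the estimated value is 15000 nM, with an expected range from 6500 nM to 35000 nM.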

Compound 3, half-maximal inhibitory concentration: 13100 nM
The estimate for compound 3 lay 1.1-fold (0.06 log units) above the measured number; low and high end bracket the measured number.
By their numbers in this assay, from the lowest: compounds 3, 2 and 1 (each within the scatter of the next).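

In this assay the methoxy in place of hydrogen on an aromatic carbon, meta to a large group and meta to a methoxy group, gives a step (a 1.3-fold lower number from compound 2 to compound 3 (0.10 log units; within the scatter)) that stays within the scatter. Unlike the earlier step, a swap of one aryl group for another, this is a single addition at one open aromatic position, and it brings no separable change in this read-out. No evidence at hand bears on this result.

As far as these compounds go, whether this position would respond differently to an amine, a carboxylic acid or a longer chain such as butoxy remains open. From the compounds shown here alone, with all three compounds read in one cytotoxicity assay only, it also remains open whether the added methoxy would leave other read-outs equally unchanged.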